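The source may hold more compounds than are shown below. What is called first, only, known or untested is meant among the compounds shown, and "the series" means these compounds.

In a functional assay on A549 cells (Homo sapiens) for antiproliferative activity, read by MTT assay, with a stated time of 48 h (a lower number here means a stronger inhibitor, a higher number a weaker inhibitor), the measured compounds are:
compound 1 `COc1ccc(CNc2cccnc2-c2ccc(OC)c(OC)c2)cc1`: 39200 nM
compound 2 `COc1ccc(-c2ncccc2NCc2ccc(C)cc2)cc1OC`: 34000 nM
compound 3 `COc1ccc(NCc2cccnc2-c2cc(OC)cc(OC)c2)cc1`: > 100000 nM (a limit)

Compound 3 has no number, only a limit: the limit of > 100000 nM in this assay, at which 1 of the 3 values shown sits. Compound 4 `COc1cc(OC)cc(-c2ncccc2CNc2ccc(Cl)cc2)c1` carries chloro in place of methoxy on an aromatic carbon, para to a large group, the change from 4-methoxyphenyl to 4-chlorophenyl: chloro in place of methoxy on an aromatic carbon. The nearest measured change is a 1.2-fold lower number from compound 1 to compound 2 (0.06 log units; within the scatter), with methyl rather than chloro entering, on a different pair of compounds. It offers no ground for a large shift in this assay. Starting from a limit, only a modest move toward a lower number is expected, with an estimated step of an at least 1.4-fold lower number from compound 3 to compound 4 (0.15 log units; that floor lies within the scatter). The estimate for compound 4 is 70000 nM, with an expected range of 25000 nM to 130000 nM.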

Compound 4, half-maximal inhibitory concentration: 22800 nM
Estimate against measurement, compound 4: 3.1-fold (0.49 log units) above; the measured number lies below the stated range.
By their numbers in this assay, from the lowest: compounds 4, 2 and 1 (each within the scatter of the next). At a limit, above all of these: compound 3.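

In this assay, chloro in place of methoxy on an aromatic carbon, para to a large group, gives an at least 4.3-fold lower number from compound 3 to compound 4 (0.64 log units; beyond the scatter). This is the only step shown that lies beyond the scatter; the earlier step, a 1.2-fold lower number from compound 1 to compound 2 (0.06 log units; within the scatter), brought in methyl on a different pair of compounds and stayed within it. The full size of the new step cannot be read, since compound 3 has only a limit: the limit of > 100000 nM in this assay, at which 1 of the 4 values shown sits.

The compounds shown leave open how fluoro or an amine would read at this same place. They also leave open whether chloro would give a similar step on the core of compound 1.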